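Chloro in place of hydrogen on compound 3

The source may report more compounds than this note shows. Statements on the series, on what has been measured and on what is new or still open speak of the compounds shown alone.

- compound 1 `CCN(CC)CN1C(=O)/C(=N/NC(=S)Nc2ccc(OC)cc2)c2ccccc21` - 4400 nM
- compound 2 `CCN(CC)CN1C(=O)/C(=N/NC(=S)Nc2ccccc2)c2ccccc21` - 8300 nM
- compound 3 `CCN(CC)CN1C(=O)/C(=N/NC(=S)Nc2ccc(C)cc2)c2ccccc21` - 12000 nM

In a functional assay on HeLa cells (Homo sapiens) for inhibition, read by cell counting, with a stated time of 96 h (on this read-out higher numbers stand for weaker inhibition and lower numbers for stronger inhibition), compound 3 gives 12000 nM. The measured steps that reach it are a 1.4-fold higher number from compound 2 to compound 3 (0.16 log units; within the scatter) and a 2.7-fold higher number from compound 1 to compound 3 (0.44 log units; beyond the scatter). The next compound, compound 4 `CCN(CC)CN1C(=O)/C(=N/NC(=S)Nc2ccc(C)cc2)c2cc(Cl)ccc21`, has chloro in place of hydrogen on an aromatic carbon of the shared core: chloro in place of hydrogen on an aromatic carbon.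

Within the data shown here, no measured step touches that part of the core. All three exchange hydrogen, methyl and methoxy on a different aromatic ring, so they bear on the new change only indirectly and give no direction for it. The largest of them, a 2.7-fold higher number from compound 1 to compound 3 (0.44 log units; beyond the scatter), is only modest, and the other two stay within the scatter. On that basis, no step beyond the scatter is expected in this assay, with only a slight, weakly supported lean towards a lower number. The expected step is a 1.5-fold lower number from compound 3 to compound 4 (0.18 log units; within the scatter). Compound 4 is estimated at 8000 nM, with an expected range of 3000 nM to 20000 nM.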

Compound 4, half-maximal inhibitory concentration: 8600 nM
Compound 4: the middle estimate sits 1.1-fold (0.03 log units) below what was measured; measured number inside the range.
By their numbers in this assay, from the lowest: compounds 1, 2, 4 and 3 (each within the scatter of the next, the first and the last beyond it).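

In this assay, this is the first change shown on the shared core rather than on the other aromatic ring, and it gives a 1.4-fold lower number from compound 3 to compound 4 (0.14 log units; within the scatter). The aromatic carbon therefore takes a chloro in place of hydrogen with no step beyond the scatter, and compound 4 cannot be told apart from compound 3 on this read-out. Nothing available accounts for the size of this step.

From the compounds shown here alone, whether a fluoro, an amine or a carboxylic acid on the same aromatic carbon would also stay within the scatter remains open. Among these compounds, also open is whether chloro behaves the same way when the other aromatic ring carries the methoxy of compound 1 or the hydrogen of compound 2, as only the pair with methyl can be read.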